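The compounds below may be only part of what the source reports. "The series", "measured", "known", "first", "only" and "open" are said of these compounds alone.

Among the compounds with values here, compound 3, `N#Cc1c(Nc2ccc(Cl)cc2)nc(SCC(=O)Nn2c(COc3ccc(Cl)cc3Cl)nc3ccccc3c2=O)nc1-c1ccc(O)cc1`, gives 77.2% in a functional assay on the whole organism (strain albino) for inhibition, with Rattus norvegicus as the target, read by paw edema, with stated times of 1 h and 2 h, at a dose of 100 mg/kg by the oral route (a higher number here means more inhibition at the dose given (going by the name of the read-out), a lower number less inhibition), the highest of the three numbers measured so far. Compound 1, `N#Cc1c(Cl)nc(SCC(=O)Nn2c(COc3ccc(Cl)cc3Cl)nc3ccccc3c2=O)nc1-c1ccc(O)cc1`, gives 73.7%, and the step of a number 3.5 percentage points higher from compound 1 to compound 3 (within the scatter) lies within the scatter, so these two are not separated. Compound 2, `N#Cc1c(Nc2ccc(O)cc2)nc(SCC(=O)Nn2c(COc3ccc(Cl)cc3Cl)nc3ccccc3c2=O)nc1-c1ccccc1`, gives 59.7%, beyond the scatter below compound 3. Compound 4, `N#Cc1c(Nc2ccc(O)cc2)nc(SCC(=O)Nn2c(COc3ccc(Cl)cc3Cl)nc3ccccc3c2=O)nc1-c1ccc(O)cc1`, differs from compound 3 by hydroxy in place of chloro on an aromatic carbon. Within the data shown here, no measured step covers this change directly; the only pointer is that compound 2 also carries the (4-hydroxyphenyl)amino group and gives 59.7%, yet compound 2 differs from compound 4 at a second place as well, so it is a weak guide. A modest downward step a number 9.2 percentage points lower from compound 3 to compound 4 (within the scatter) is therefore expected. Compound 4 is estimated at 68%, with a range from 54% to 80%.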

Compound 4, a percentage reported as inhibition, in the whole organism at one dose (the size of the read-out at that dose, not a potency): 86.8%
Compound 4: middle estimate off by 18.8 percentage points, on the low side, outside the stated range (above it).
By their numbers in this assay, from the lowest: compound 2; then compounds 1, 3 and 4 (each within the scatter of the next, the first and the last beyond it).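

In this assay, hydroxy in place of chloro at this position gives a number 9.6 percentage points higher from compound 3 to compound 4 (within the scatter) and so does not separate (4-hydroxyphenyl)amino from (4-chlorophenyl)amino. The (4-hydroxyphenyl)amino group in place of chloro on the core gives a number 13.1 percentage points higher from compound 1 to compound 4 (beyond the scatter) as a step beyond the scatter, which (4-chlorophenyl)amino did not give. Hydroxy in place of hydrogen on the other phenyl ring gives a number 27.1 percentage points higher from compound 2 to compound 4 (beyond the scatter) and is likewise beyond the scatter.

From the compounds shown here alone, whether methoxy or an amine at this position would stay level with hydroxy and chloro remains open. Nothing available bears on the reason for these steps.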